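The source may hold more compounds than are shown below. What is called first, only, known or untested is meant among the compounds shown, and "the series" means these compounds.

Three compounds sharing one core were examined in a functional assay on MKN-45 cells (Homo sapiens) for antiproliferative activity, read by MTT assay, with a stated time of 72 h, tested at 10 uM; a higher number here means more inhibition at the concentration tested (going by the name of the read-out), a lower number less inhibition. Compound 2 `CC(C)C(=O)Nc1cc(Oc2ccc(Nc3nccc4[nH]cc(-c5ccc(F)cc5)c(=O)c34)cc2F)ccn1` gives 95.4% in this assay. Compound 1 `CC(O)C(=O)Nc1cc(Oc2ccc(Nc3nccc4[nH]cc(-c5ccc(F)cc5)c(=O)c34)cc2F)ccn1` gives 67.3%, and the step of a number 28.1 percentage points lower from compound 2 to compound 1 (beyond the scatter) is the change (hydroxy in place of methyl on a saturated chain carbon bound to a carbonyl carbon and a saturated chain carbon). Compound 3 `CC(C)(C)C(=O)Nc1cc(Oc2ccc(Nc3nccc4[nH]cc(-c5ccc(F)cc5)c(=O)c34)cc2F)ccn1` gives 62.5%, reached by a number 32.9 percentage points lower from compound 2 to compound 3 (beyond the scatter), the change being (methyl in place of hydrogen on a saturated chain carbon bound to a carbonyl carbon and two saturated chain carbons). Between compound 1 and compound 3 the step of a number 4.8 percentage points lower from compound 1 to compound 3 (within the scatter) lies within the scatter, so no order between them is claimed.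

The unmeasured compound 4 `CC(C)(O)C(=O)Nc1cc(Oc2ccc(Nc3nccc4[nH]cc(-c5ccc(F)cc5)c(=O)c34)cc2F)ccn1` differs from compound 3 by hydroxy in place of methyl on a saturated chain carbon bound to a carbonyl carbon and two saturated chain carbons. Going by the values given here, this is the same kind of change as the one from compound 2 to compound 1, although the place is not identical: in the earlier pair the carbon carrying the change is bound to a carbonyl carbon and a saturated chain carbon, while here it is bound to a carbonyl carbon and two saturated chain carbons. The cores of compound 3 and compound 2 differ by methyl in place of hydrogen on a saturated chain carbon bound to a carbonyl carbon and two saturated chain carbons.

Because a number 28.1 percentage points lower from compound 2 to compound 1 (beyond the scatter) was a modest drop beyond the scatter, a drop of comparable size is expected for compound 4, though the starting point of compound 3 is already the lowest of the three. The expected step is a number 20.5 percentage points lower from compound 3 to compound 4 (beyond the scatter). Compound 4 is thus estimated at 42%, with a likely range from 22% to 64%.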

Compound 4, a percentage reported as inhibition, at one concentration (the size of the read-out at that concentration, not a potency): 57.8%
For compound 4 the middle estimate is 15.8 percentage points below the measured one; the range from low to high includes it.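

In this assay hydroxy in place of methyl does not carry a fixed step from one core to another, as the drop on the core of compound 2 does not reappear on the core of compound 3, where the step is a number 4.7 percentage points lower from compound 3 to compound 4 (within the scatter): the same change on two cores in this assay, a number 28.1 percentage points lower (beyond the scatter) from compound 2 to compound 1 and a number 4.7 percentage points lower (within the scatter) from compound 3 to compound 4, 23.4 percentage points apart, beyond the scatter of two such steps The reverse reading of the same square gives the same answer, since methyl in place of hydrogen gives a number 9.5 percentage points lower from compound 1 to compound 4 (within the scatter) on the hydroxy-bearing side, which differs from the step on the side without hydroxy: the same change on two cores in this assay, a number 32.9 percentage points lower (beyond the scatter) from compound 2 to compound 3 and a number 9.5 percentage points lower (within the scatter) from compound 1 to compound 4, 23.4 percentage points apart, beyond the scatter of two such steps Taking both changes together gives a number 37.6 percentage points lower from compound 2 to compound 4 (beyond the scatter), which shows that within these four compounds the size of each step depends on what else stands on the carbon bound to the carbonyl carbon, but it does not show why, and a read-out at one concentration in one cell line says nothing about potency.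

The compounds shown leave open whether this dependence on the core would also hold for an amine or a methoxy in place of the hydroxy. They also leave open how a longer chain or a cyclopropyl on the carbonyl carbon would fit into this pattern.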